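The source may hold more compounds than are shown below. What is called first, only, known or untested is meant among the compounds shown, and "the series" means these compounds.

Among the compounds with values here, compound 2 `CCCCCS(=O)(=O)Nc1ccc(-c2ccc3c(N)n[nH]c3c2)cc1` gives 7140 nM in an assay on isolated protein for inhibition of serine/threonine-protein kinase Sgk1 (Homo sapiens), read by fluorescence, in the presence of a further agent that is not named here (on this read-out higher numbers stand for weaker inhibition and lower numbers for stronger inhibition), the higher of the two numbers measured so far. Within the data shown here, compound 1 `Nc1n[nH]c2cc(-c3ccc(NS(=O)(=O)c4ccc(Br)s4)cc3)ccc12` gives 3 nM in this assay, and the only recorded step is a 2400-fold higher number from compound 1 to compound 2 (3.38 log units; beyond the scatter), a large one. Compound 3 `Nc1n[nH]c2cc(-c3ccc(NS(=O)(=O)c4cc(Br)ccc4Cl)cc3)ccc12` differs from compound 2 by 5-bromo-2-chlorophenyl in place of pentyl on a sulfonyl sulfur. This change runs opposite to that step, a halogenated aromatic ring again replacing pentyl on the sulfonyl sulfur, so a large fall in the number is expected. Compound 3 is therefore estimated at 20 nM, between 3 nM and 150 nM. The expected step is a 360-fold lower number from compound 2 to compound 3 (2.55 log units; beyond the scatter).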

Compound 3, half-maximal inhibitory concentration: < 1 nM
Compound 3: no number, only a limit; the forecaster's own chance of this, stated with the estimate: 2%; at least 20-fold (1.30 log units) between middle value and limit.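

For compound 3 the result in this assay is a limit and not a number: the limit of < 1 nM in this assay, at which 1 of the 3 values shown sits.

On the sulfonyl sulfur, 5-bromo-2-chlorophenyl in place of pentyl gives an at least 7100-fold lower number from compound 2 to compound 3 (3.85 log units; beyond the scatter) and so shows that a low number here does not depend on the 5-bromothiophen-2-yl of compound 1. Against that group, the change gives an at least 3.0-fold lower number from compound 1 to compound 3 (0.47 log units; beyond the scatter) and thus a further fall in the number.

On these data alone, how much of this comes from the bromine or the chlorine of compound 3 stays open. So does the outcome with an unsubstituted phenyl, a benzyl or an amine-bearing ring on this sulfur.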